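Cyclohexyl in Place of Methoxycarbonyl: Expected Cytotoxicity of Compound 4

A few compounds are considered here, and "the series" means these few. Any claim that something is new, unique, unknown or untested is made for them only; others in the source may bear on it.

Measured compounds:
compound 1 `CCC1(Cc2ccccc2)OS(=O)(=O)C=C1OCC(=O)OC` — > 400000 nM
compound 2 `CCC1(Cc2ccccc2)OS(=O)(=O)C=C1OCc1ccccc1` — >= 50000 nM
compound 3 `CCC1(Cc2ccccc2)OS(=O)(=O)C=C1OCc1ccc(C)cc1` — >= 16000 nM

Three compounds sharing one core were tested in an ADME assay on HEL cells (Homo sapiens) for cytotoxicity, with a stated time of 3 days; on this read-out higher numbers stand for lower toxicity in this test and lower numbers for higher toxicity in this test. Compound 1 gives > 400000 nM, which is a limit of the assay and not a number. Compound 2 gives >= 50000 nM, also a limit. Compound 3 gives >= 16000 nM, again a limit. Compound 1 therefore stands only as a limit among three limits, and none of the steps between the measured compounds can be read: a step that the two limits leave unreadable from compound 1 to compound 2, a step that the two limits leave unreadable from compound 1 to compound 3 and a step that the two limits leave unreadable from compound 2 to compound 3 are all unreadable. The evidence is only (the limit of > 400000 nM in this assay, at which 1 of the 3 values shown sits), the limit of >= 50000 nM in this assay, at which 1 of the 3 values shown sits, and (the limit of >= 16000 nM in this assay, at which 1 of the 3 values shown sits).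

Compound 4 `CCC1(Cc2ccccc2)OS(=O)(=O)C=C1OCC1CCCCC1` carries the change (cyclohexyl in place of methoxycarbonyl on a saturated chain carbon bound to an oxygen on an unsaturated carbon). Among the compounds with values here, the steps that bear on it, from compound 1 to compound 2 and to compound 3, also replace methoxycarbonyl on the same saturated chain carbon, but their size is not readable, so no direction can be taken from them. Compound 4 is therefore expected to show no readable step beyond the scatter; the estimate for compound 4 is 100000 nM, with a range from 16000 nM to 400000 nM, meaning an expected step of an at least 4.0-fold lower number from compound 1 to compound 4 (0.60 log units; beyond the scatter).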

Compound 4, minimum cytotoxic concentration: >= 200000 nM
Compound 4 was reported as a limit; the forecaster's own chance of this, stated with the estimate: 80%; at least 2.0-fold (0.30 log units) between middle value and limit.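

Compound 4 gives >= 200000 nM, which is a limit of the assay and not a number. Within the data shown here, as the values of compound 1, compound 2 and compound 3 are limits too, no step to compound 4 can be read. The compounds shown leave open whether cyclohexyl, phenyl, 4-methylphenyl or methoxycarbonyl on this chain carbon changes the cytotoxicity at all.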